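Shortening One Alkyl Arm on the Shared Core

The source may report more compounds than this note shows. Statements on the series, on what has been measured and on what is new or still open speak of the compounds shown alone.

Compound 1 `CCCn1c(=O)c2nc(C(O)(CC)CC)[nH]c2n(CCC)c1=O` carries a 1-ethyl-1-hydroxypropyl group on an aromatic carbon of the shared core. In an assay on cell membranes for binding affinity to adenosine receptor A1 (Cavia porcellus), read by radioligand binding (a higher number here means a weaker inhibitor, a lower number a stronger inhibitor), compound 1 gives 170 nM, the highest of the two numbers in view. Compound 2 `CC(C)(C)CNc1ncnc2c1ncn2C1O[C@H](CO)[C@@H](O)[C@H]1O` gives 17 nM in this assay, a lower number beyond the scatter. Compound 3 `CCCn1c(=O)c2nc(-c3nn[nH]n3)[nH]c2n(CCC)c1=O` sits at a limit of this assay, > 10000 nM, so its number is not known. The step of an at least 58-fold higher number from compound 1 to compound 3 (1.76 log units; beyond the scatter) is large, and the limit of > 10000 nM in this assay, at which 1 of the 3 values shown sits, marks where that step ends. Compound 4 `CCCn1c(=O)c2nc(C(C)(O)CC)[nH]c2n(CCC)c1=O` differs from compound 1 by hydrogen in place of methyl on a saturated chain carbon, two bonds along the chain from an aromatic carbon and an oxygen on a saturated carbon, so the group is trimmed by one carbon but keeps its hydroxyl and its branching. Going by the values given here, the only measured step replaces the whole group with a 2H-tetrazol-5-yl ring, a far larger change than the loss of a single methyl, so it bears on this step only loosely. The step of a 1.2-fold higher number from compound 1 to compound 4 (0.07 log units; within the scatter) is therefore expected to stay within the scatter. Compound 4 is estimated at 200 nM, between 80 nM and 500 nM.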

Compound 4, inhibition constant: 240 nM
Estimate against measurement, compound 4: 1.2-fold (0.08 log units) below, and the stated range covers the measured number.
By their numbers in this assay, from the lowest: compound 2; then compounds 1 and 4 (each within the scatter of the next). At a limit, above all of these: compound 3.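

In this assay, the step of a 1.4-fold higher number from compound 1 to compound 4 (0.15 log units; within the scatter) lies within the scatter, so 1-hydroxy-1-methylpropyl and 1-ethyl-1-hydroxypropyl on this aromatic carbon cannot be told apart, whereas the earlier step at this position had shown only a large change. The step of an at least 41-fold lower number from compound 3 to compound 4 (1.61 log units; beyond the scatter) is also large, so the trimmed group stands apart from 2H-tetrazol-5-yl just as the untrimmed group does. The true size of that step remains open, as the value of compound 3 is a limit and not a number: the limit of > 10000 nM in this assay, at which 1 of the 4 values shown sits.

The compounds shown leave open how far the chain can change in either direction, for example with a longer chain such as 1-hydroxy-1-propylbutyl. They also leave open what an amine or a carboxylic acid would do at this position.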